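Saturated substituent variation at the aromatic nitrogen

This account rests on a few compounds, and the source may have more. Where it says the series, first, only, none or still open, it means among the compounds named here.

Compound 3 `CCCCCn1c(Cc2cc(OC)c(OC)c(OC)c2)nc2c(N)ncnc21` carries a butyl group on a saturated chain carbon bound to an aromatic nitrogen. Among the compounds with values here, in a functional assay on MCF7 cells (Homo sapiens) for antiproliferative activity (on this read-out higher numbers stand for weaker inhibition and lower numbers for stronger inhibition), compound 3 gives 61700 nM, the highest of the three numbers measured so far. Compound 2 `CCCn1c(Cc2cc(OC)c(OC)c(OC)c2)nc2c(N)ncnc21` gives 46800 nM in this assay, and compound 1 `COc1cc(Cc2nc3c(N)ncnc3n2CC2CCCCC2)cc(OC)c1OC` gives 39800 nM. The three steps that connect them, a 1.2-fold higher number from compound 1 to compound 2 (0.07 log units; within the scatter), a 1.6-fold higher number from compound 1 to compound 3 (0.19 log units; within the scatter) and a 1.3-fold higher number from compound 2 to compound 3 (0.12 log units; within the scatter), all lie within the scatter, so no order among compounds 1, 2 and 3 can be read from these values.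

Within the data shown here, compound 4 `COc1cc(Cc2nc3c(N)ncnc3n2CC2CC2)cc(OC)c1OC` is the next member. cyclopropyl in place of butyl on a saturated chain carbon bound to an aromatic nitrogen The steps that bear on this exchange are the two that also swap the group at this place: a 1.6-fold higher number from compound 1 to compound 3 (0.19 log units; within the scatter) moves from a ring to a chain, and a 1.2-fold higher number from compound 1 to compound 2 (0.07 log units; within the scatter) moves from a ring to a shorter chain, while a 1.3-fold higher number from compound 2 to compound 3 (0.12 log units; within the scatter) lengthens the chain; none of them moved this assay beyond the scatter. Nothing in the measured set separates a ring from a chain at this place, so the step from compound 3 to compound 4 is expected to stay within the scatter, a 1.2-fold lower number from compound 3 to compound 4 (0.09 log units; within the scatter). Compound 4 is therefore expected to give 50000 nM, with a range from 20000 nM to 120000 nM.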

Compound 4, half-maximal inhibitory concentration: 75900 nM
The estimate for compound 4 lay 1.5-fold (0.18 log units) below the measured number; low and high end bracket the measured number.
By their numbers in this assay, from the lowest: compounds 1, 2, 3 and 4 (each within the scatter of the next).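

The three-membered ring of compound 4 extends the comparison in this assay: cyclopropyl in place of butyl gives a 1.2-fold higher number from compound 3 to compound 4 (0.09 log units; within the scatter), cyclopropyl in place of ethyl gives a 1.6-fold higher number from compound 2 to compound 4 (0.21 log units; within the scatter), and cyclopropyl in place of cyclohexyl gives a 1.9-fold higher number from compound 1 to compound 4 (0.28 log units; within the scatter). Cyclohexyl was the only ring at this place in the earlier compounds, and even the exchange between the two rings, the largest of the steps in the set, does not pass the scatter, so the set shows no separation by ring size or between rings and chains on a saturated chain carbon bound to an aromatic nitrogen. No supporting information on the cause of these values is available for this series.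

All saturated carbon groups at this place thus remain indistinguishable, leaving open whether an amine, a carboxylic acid, a phenyl ring or a longer chain such as decyl would produce a step beyond the scatter in this assay. From the compounds shown here alone, it also remains open whether changes elsewhere, such as replacing the methoxy groups with hydroxyl groups, would move the number further than any exchange at this place has done.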